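The compounds below may be only part of what the source reports. "The series", "measured", "known", "first", "only" and "open" are said of these compounds alone.

Measured so far in an ADME assay on Huh-7 cells (Homo sapiens) for cytotoxicity; a lower number here means a stronger inhibitor of growth, a higher number a weaker inhibitor of growth:

- compound 1 `COc1cc2c(=O)c(C(=O)c3ccc(C)cc3)cn(Cc3ccc(N)cc3)c2cc1OC`; compound 1 gives "not active" (no number reported)
- compound 2 `COc1cc2c(=O)c(C(=O)c3ccc(C)cc3)cn(CCCc3ccccc3)c2cc1OC`; compound 2 gives "not active" (no number reported)
- compound 3 `COc1cc2c(=O)c(C(=O)c3ccc(C)cc3)cn(Cc3ccc(S(C)(=O)=O)cc3)c2cc1OC`; for compound 3 the result is a limit of the assay, not a number: > 50000 nM

Compound 1 therefore has no single number in this assay; of the two further results, one is a limit and the other is again an entry without a number. Put together, (the limit of > 50000 nM in this assay, at which 1 of the 3 values shown sits).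

Compound 4 `COc1cc2c(=O)c(C(=O)c3ccc(C)cc3)cn(Cc3ccc(Cl)cc3)c2cc1OC` differs from compound 1 by chloro in place of amino on an aromatic carbon. Among the compounds with values here, no measured pair shows this change, so no direction can be read from the data; in this assay the step is expected to be none beyond the usual scatter. For compound 4 the estimate in this assay is 70000 nM, with a range from 20000 nM to 250000 nM.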

Compound 4, concentration for 50% growth inhibition: 15500 nM
Estimate against measurement, compound 4: 4.5-fold (0.65 log units) above; measured number outside the range, below it.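

In this assay compound 4 gives 15500 nM, the only actual number among the compounds shown. Chloro in place of methylsulfonyl on the aromatic carbon gives an at least 3.2-fold lower number from compound 3 to compound 4 (0.50 log units; beyond the scatter), so the group at this place on the ring does change growth inhibition. Compound 3 stands only at a limit of the assay, so the full size of this step stays unknown: the limit of > 50000 nM in this assay, at which 1 of the 4 values shown sits.

Compound 1 and compound 2 have no number, so steps involving them cannot be read. As far as these compounds go, whether bromo, methoxy or a carboxylic acid at this place would follow chloro remains open.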